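The compounds below may be only part of what the source reports. "The series", "measured", "known", "first", "only" and "open" are said of these compounds alone.

Among the measured compounds shown here, in an assay on Prostate gland for inhibition of steroid 5-alpha-reductase (Rattus norvegicus) (a lower number here means a stronger inhibitor, a higher number a weaker inhibitor), compound 3 `CCCC(CC)n1ccc2cc(/C(C)=C/C(=O)Nc3ccccc3OCCCC(=O)O)ccc21` gives 9.3 nM, the lowest of the three numbers measured so far. Compound 1 `CCCCn1ccc2cc(/C(C)=C/C(=O)Nc3ccccc3OCCCC(=O)O)ccc21` gives 43 nM and compound 2 `CCC(C)n1ccc2cc(/C(C)=C/C(=O)Nc3ccccc3OCCCC(=O)O)ccc21` gives 67 nM; the step of a 1.6-fold higher number from compound 1 to compound 2 (0.19 log units; within the scatter) lies within the scatter, so no order between compound 1 and compound 2 is read from it. The two steps that lead to compound 3, a 4.6-fold lower number from compound 1 to compound 3 (0.66 log units; beyond the scatter) and a 7.2-fold lower number from compound 2 to compound 3 (0.86 log units; beyond the scatter), both lower the number beyond the scatter, and both put more carbon onto the chain that sits on the aromatic nitrogen.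

Compound 4 `CCCCC(CCCC)n1ccc2cc(/C(C)=C/C(=O)Nc3ccccc3OCCCC(=O)O)ccc21` carries the change (1-butylpentyl in place of 1-ethylbutyl on an aromatic nitrogen). For the measured compounds named here, no measured step starts from a chain as large as 1-ethylbutyl, so this move is not covered directly. The steps from compound 1 and from compound 2 to compound 3 lowered the number as that chain grew, and on that basis a further modest lowering, or a step within the scatter, is expected for compound 4; the data do not secure the direction for a chain of this size. For compound 4 in this assay the estimate is 7 nM, expected to fall between 2 nM and 25 nM. That estimate means an expected step of a 1.3-fold lower number from compound 3 to compound 4 (0.12 log units; within the scatter) from compound 3 to compound 4.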

Compound 4, half-maximal inhibitory concentration: 21 nM
Compound 4: middle estimate off by 3.0-fold (0.48 log units), on the low side; the range from low to high includes it.
By their numbers in this assay, from the lowest: compound 3; then compound 4; then compounds 1 and 2 (each within the scatter of the next).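

In this assay, among the compounds shown here, the change from 1-ethylbutyl to 1-butylpentyl on the aromatic nitrogen gives a 2.3-fold higher number from compound 3 to compound 4 (0.35 log units; beyond the scatter) and so ends the lowering that came with added carbon on this chain in the earlier steps. The largest chain still stands lower than the two smallest, with a 3.2-fold lower number from compound 2 to compound 4 (0.50 log units; beyond the scatter) and a 2.0-fold lower number from compound 1 to compound 4 (0.31 log units; beyond the scatter) so the number does not follow chain size in one direction across these four compounds, and compound 3 with its 1-ethylbutyl chain is the lowest, its steps to all three others lying beyond the scatter. No measurement is available that bears on the reason for this turn.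

The compounds shown leave open how a 1-propylbutyl chain, which lies in size between the 1-ethylbutyl and 1-butylpentyl chains, would stand on the aromatic nitrogen, and so whether compound 3 marks the lowest point of this branched series. They also leave open whether a cyclohexyl ring in the same place would keep a number as low as that of compound 3 or lose it as the 1-butylpentyl chain did.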